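This account rests on a few compounds, and the source may have more. Where it says the series, first, only, none or still open, it means among the compounds named here.

Measured so far in an ADME assay on BJ cells (Homo sapiens) for cytotoxicity, read by CellTiter-Glo and resazurin assay, with a stated time of 72 h; on this read-out lower numbers stand for an effect already at smaller amounts and higher numbers for an effect only at larger amounts of compound:

compound 1 `CCOC(=O)CCCCCOc1cccc(CN(C(=O)c2ccc(-c3cccc(NC(C)=O)c3)cc2)C(C)C)c1` — in this assay compound 1 reaches only a limit, > 26000 nM.

compound 2 `CCOC(=O)CCCCCOc1cccc(CN(C(=O)c2ccc(-c3ccc4c(c3)OCCO4)cc2)C(C)C)c1` — in this assay compound 2 likewise reaches only a limit, > 24400 nM.

For the measured compounds named here, compound 2 therefore stands at a limit rather than at a number, and the one further value shown is also a limit. The step that the two limits leave unreadable from compound 1 to compound 2 stays unreadable, since one end sits at the limit of > 24400 nM in this assay, at which 1 of the 2 values shown sits, and the other at the limit of > 26000 nM in this assay, at which 1 of the 2 values shown sits.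

Compound 3 `CCOC(=O)CCCCCOc1cccc(CN(C(=O)c2ccc(-c3cccc(Br)c3)cc2)C(C)C)c1` differs from compound 2 by 3-bromophenyl in place of 2,3-dihydro-1,4-benzodioxin-6-yl on an aromatic carbon.

Going by the values given here, only one measured step touches this part of the molecule, and its size cannot be read. The expected step that the limit leaves unreadable from compound 2 to compound 3 is accordingly none beyond the scatter. Compound 3 is estimated at 25000 nM, within a range from 8000 nM to 60000 nM, and most likely only a limit will again be reported.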

Compound 3, half-maximal effective concentration: > 26000 nM
Compound 3: no number, only a limit (the forecaster's own chance of this, stated with the estimate: 70%); middle value at least 1.0-fold (0.01 log units) away from the limit.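

For the compounds shown here, compound 3 also reaches only a limit, so no step among compound 1, compound 2 and compound 3 can be read. The compounds shown leave open at what concentration any of them would affect these cells, and whether exchanging these groups changes that concentration at all.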